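A few compounds are considered here, and "the series" means these few. Any claim that something is new, unique, unknown or untested is made for them only; others in the source may bear on it.

Measured so far in a functional assay (MiaPaCa cells, Homo sapiens) for inhibition, read by sulforhodamine B assay, with a stated time of 48 h; on this read-out higher numbers stand for weaker inhibition of growth and lower numbers for stronger inhibition of growth:

Compound 1, `O=C(N/N=C\c1ccc(Cl)cc1)C1=C(Cl)c2ccccc2CCC1`: < 10 nM. This value is a limit of the assay, not a measured number.
Compound 2, `Cc1cc2c(cc1C)C(Cl)=C(C(=O)N/N=C\c1ccc(Cl)cc1)CCC2`: 440 nM.
Compound 3, `O=C(N/N=C/C1=C(Cl)c2ccccc2CCC1)c1ccccc1`: 1000 nM.

Of the two real numbers in this assay, compound 3 holds the higher one, meaning the weaker inhibition of growth. Its nearest neighbour is compound 2, whose number is lower, and the gap between the two lies beyond the usual scatter of repeated measurements. Compound 1 sits at the assay's limit, so its place relative to the others is not a number.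

The compound still to be measured is compound 4, `Nc1ccccc1C(=O)N/N=C/C1=C(Cl)c2ccccc2CCC1`. It differs from compound 3 in one place: amino in place of hydrogen on an aromatic carbon. For the measured compounds named here, no pair of measured compounds shows this same change, so there is no measured step to lean on; the only guide is that the shared core and the hydrazone linkage are unchanged. On that basis, in this assay a step of a 1.3-fold lower number from compound 3 to compound 4 (0.10 log units; within the scatter) is expected, one that stays within the usual scatter rather than beyond it. Compound 4 is accordingly estimated at 800 nM, with a range from 250 nM to 2500 nM.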

Compound 4, concentration for 50% growth inhibition: 65100 nM
Beside the measured number, compound 4's estimate is 81-fold (1.91 log units) below it, and the stated range ends below it.
By their numbers in this assay, from the lowest: compound 2; then compound 3; then compound 4. At a limit, below all of these: compound 1.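

Changing phenyl to 2-aminophenyl, on an aromatic carbon ortho to a large group, gives in this assay a 65-fold higher number from compound 3 to compound 4 (1.81 log units; beyond the scatter). This is the first step shown between compounds that differ in one place, and it shows that this aromatic ring does not tolerate every change: the entry of a single nitrogen atom, as an amino group, weakens growth inhibition far more than the usual scatter of repeated measurements can account for, while the shared core and the hydrazone linkage stay the same. The measurements shown offer no explanation for the size of this step.

From the compounds shown here alone, it remains open whether the loss belongs to the amino group itself or would follow any group placed on this carbon, and a methyl, a hydroxyl or a fluorine there would help to separate those two readings. Going by these compounds, it is also open whether an amino group on another carbon of this ring, or an acetylamino group on the same carbon, would give a step of similar size.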